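The source may report more compounds than this note shows. Statements on the series, on what has been measured and on what is new or still open speak of the compounds shown alone.

Within the data shown here, in an ADME assay on HepG2 cells (Homo sapiens) for cytotoxicity, read by XTT assay, with a stated time of 2 days (a lower number here means that less compound is tolerated, a higher number that more compound is tolerated), compound 1 (`Cc1cc(NC(=O)c2sc(N)c(C#N)c2C)ccc1F`) gives 96000 nM and provides the only number so far. Compound 2 (`Cc1ccc(NC(=O)c2sc(N)c(C(N)=O)c2C)cc1`) offers no such anchor: its result in this assay stands as "not determined" (no result reported) and it cannot be ranked against compound 1. Compound 3 (`Cc1c(C(=O)Nc2ccc(F)cc2)sc(N)c1C(N)=O`) has yet to be measured. The structural change is fluoro in place of methyl on an aromatic carbon and amounts to fluoro in place of methyl on an aromatic carbon, para to a large group. With no number for compound 2, the size of this step cannot be read from the data. No step beyond the usual scatter is expected in this assay, so no direction is assigned to it. This expectation leans on compound 1 at 96000 nM alone, a single related structure that also carries fluoro on a six-membered aromatic ring of carbon only, so it remains weak. For compound 3 the estimated half-maximal cytotoxic concentration is 80000 nM with an expected range from 30000 nM to 200000 nM in this series.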

Compound 3, half-maximal cytotoxic concentration: > 100000 nM
Compound 3 ended at the assay's limit; the forecaster's own chance of this, stated with the estimate: 30%; middle value at least 1.2-fold (0.09 log units) away from the limit.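

Among these compounds, compound 2 has no number in this assay, and no step from it to compound 3 can be read. Compound 3 gives > 100000 nM, which is a limit of the assay and not a number. The compounds shown leave open what fluoro in place of methyl, para to a large group, does to the tolerated concentration.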